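The source may report more compounds than this note shows. Statements on the series, on what has been measured and on what is new or still open speak of the compounds shown alone.

Compound 1 `COc1ccc2nc(C)cc(OCC(=O)Nc3c(C)cccc3C)c2c1` is the more soluble of the two measured compounds: in a physicochemical assay for solubility, in phosphate buffer, measured as kinetic solubility, with a stated time of 1 h, at pH 7.4 (on this read-out lower numbers stand for lower solubility and higher numbers for higher solubility), compound 1 gives 112000 nM, while compound 2 `COc1ccc2nc(C)cc(OCC(=O)Nc3cc(OC)c(Cl)cc3OC)c2c1` gives 3000 nM in this assay, a gap well beyond the scatter. Compound 3 `COc1ccc2nc(C)cc(OCC(=O)Nc3nccs3)c2c1` has not been measured yet. It differs from compound 1 in one place: 1,3-thiazol-2-yl in place of 2,6-dimethylphenyl on an amide-type nitrogen. The entering group is smaller and carries hydrogen-bond acceptors where the leaving group had none, so the step of a 1.1-fold lower number from compound 1 to compound 3 (0.05 log units; within the scatter) is expected to be small, in either direction, within the scatter. Compound 3 is estimated at 100000 nM, with a range from 30000 nM to 250000 nM.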

Compound 3, solubility: 54000 nM
For compound 3 the middle estimate is 1.9-fold (0.27 log units) above the measured one; low and high end bracket the measured number.
By their numbers in this assay, from the lowest: compound 2; then compound 3; then compound 1.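

In this assay, for the compounds shown here, the change at this amide-type nitrogen from 2,6-dimethylphenyl to 1,3-thiazol-2-yl gives a 2.1-fold lower number from compound 1 to compound 3 (0.32 log units; beyond the scatter) and gives the first single-place comparison at this position. The entering group is smaller and carries hydrogen-bond acceptors, yet the number falls rather than rises. No measurement available here explains the direction of this step. Still open, on these data alone, is how a pyridine ring, or a phenyl ring carrying an amine or a carboxylic acid, would compare at this nitrogen. A single step also cannot show whether other five-membered aromatic rings would behave like 1,3-thiazol-2-yl.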